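The source may hold more compounds than are shown below. What is called first, only, known or untested is meant among the compounds shown, and "the series" means these compounds.

Compound 1 `COc1ccc(-c2nc3cccc(-c4cc(OC)c(OC)c(OC)c4)c3o2)cc1OC` gives 2800 nM in a functional assay on A549 cells (Homo sapiens) for antiproliferative activity, read by MTT assay, with a stated time of 48 h (on this read-out lower numbers stand for stronger inhibition and higher numbers for weaker inhibition), the lowest of the three numbers recorded, though not separated from the others beyond the scatter. Compound 2 `COc1cc(-c2cccc3nc(-c4ccc(Cl)cc4)oc23)cc(OC)c1OC` gives 5600 nM in this assay, and compound 3 `COc1cc(-c2cccc3nc(-c4cccc(N)c4)oc23)cc(OC)c1OC` gives 4700 nM. Compound 4 `COc1cc(-c2cccc3nc(-c4cccs4)oc23)cc(OC)c1OC` differs from compound 1 by thiophen-2-yl in place of 3,4-dimethoxyphenyl on an aromatic carbon. The two steps that bear on this also swap the 3,4-dimethoxyphenyl for another aromatic ring, and both stayed within the scatter: a 2.0-fold higher number from compound 1 to compound 2 (0.30 log units; within the scatter) and a 1.7-fold higher number from compound 1 to compound 3 (0.22 log units; within the scatter). A step of similar size, toward a slightly higher number, is therefore expected for compound 4, as a 1.4-fold higher number from compound 1 to compound 4 (0.15 log units; within the scatter). Compound 4 is estimated at 4000 nM in this assay, within a range from 1500 nM to 11000 nM.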

Compound 4, half-maximal inhibitory concentration: 12500 nM
For compound 4 the middle estimate is 3.1-fold (0.49 log units) below the measured one; the whole stated range lies below it.
By their numbers in this assay, from the lowest: compounds 1, 3 and 2 (each within the scatter of the next); then compound 4.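

Among the compounds shown here, at the aromatic carbon next to the ring nitrogen and the ring oxygen, thiophen-2-yl is the first replacement that separates from the others in this assay: a 4.5-fold higher number from compound 1 to compound 4 (0.65 log units; beyond the scatter), a 2.7-fold higher number from compound 3 to compound 4 (0.42 log units; beyond the scatter) and a 2.2-fold higher number from compound 2 to compound 4 (0.35 log units; beyond the scatter). Compounds 1, 2 and 3, all with substituted phenyl rings here, stayed within the scatter of one another, so this place does respond to the ring it carries, though only modestly. Nothing available accounts for the difference.

As far as these compounds go, it remains open whether furan-2-yl, with oxygen in place of sulfur, would stay close to compound 4 or return to the range of compounds 1, 2 and 3. Unsubstituted phenyl and pyridin-3-yl at this place are equally open.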